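Formalin-test urea series: the step from compound 3 to compound 4

This account rests on a few compounds, and the source may have more. Where it says the series, first, only, none or still open, it means among the compounds named here.

Measured so far in a functional assay on the whole organism (strain Swiss albino) for inhibition, with Mus musculus as the target, in the formalin test, with a stated time of 30 min, at a dose of 100 mg/kg; a higher number here means more inhibition at the dose given (going by the name of the read-out), a lower number less inhibition:
compound 1, `CCN1CCc2c(c(C)nn2C(=O)Nc2ccc(Br)cc2)C1`, 81.6%
compound 2, `CCN1CCc2c(c(C)nn2C(=O)Nc2c(C)cccc2C)C1`, 78.9%
compound 3, `CCN1CCc2c(c(C(C)(C)C)nn2C(=O)Nc2ccc(Br)cc2)C1`, 72.1%

Compound 3 carries the lowest of the three numbers in this assay, but its nearest neighbour compound 2 and the furthest, compound 1, both sit within the scatter of it, so no order among the three can be read. For the measured compounds named here, the one single-point step available is a number 9.5 percentage points lower from compound 1 to compound 3 (within the scatter); it does not reach beyond the scatter.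

Compound 4, `CCN1CCc2c(c(C(C)(C)C)nn2C(=O)Nc2c(C)cccc2C)C1`, is still unmeasured in this assay. It differs from compound 3 by 2,6-dimethylphenyl in place of 4-bromophenyl on an amide-type nitrogen. Going by the values given here, no step for this exact change has been measured. The closest information comes from compound 1 and compound 2, which differ in the same part of the molecule while sharing the methyl group: compound 1 gives 81.6% and compound 2 gives 78.9%, two values within the scatter of each other. On that basis no movement beyond the scatter is expected for a number 2.1 percentage points lower from compound 3 to compound 4 (within the scatter), and compound 4 is estimated at 70%, with a range from 58% to 82%.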

Compound 4, a percentage reported as inhibition, in the whole organism at one dose (the size of the read-out at that dose, not a potency): 68%
Estimate against measurement, compound 4: 2 percentage points above, and the stated range covers the measured number.
By their numbers in this assay, from the lowest: compounds 4, 3, 2 and 1 (each within the scatter of the next, the first and the last beyond it).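

In this assay, 2,6-dimethylphenyl in place of 4-bromophenyl on an amide-type nitrogen gives a number 4.1 percentage points lower from compound 3 to compound 4 (within the scatter), so with tert-butyl on the shared core this exchange stays inside the scatter; with methyl in that place, compound 1 stands at 81.6% and compound 2 at 78.9%. Tert-butyl in place of methyl on an aromatic carbon now gives a number 10.9 percentage points lower from compound 2 to compound 4 (beyond the scatter), the first step of this change to pass beyond the scatter, though only modestly. The change can now be read on two cores, with one step inside the scatter and one just beyond it, and their sizes agree: the same change on two cores in this assay, a number 9.5 percentage points lower (within the scatter) from compound 1 to compound 3 and a number 10.9 percentage points lower (beyond the scatter) from compound 2 to compound 4, 1.4 percentage points apart, within the scatter of two such steps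

Open, on these data alone, is what ethyl or isopropyl on that aromatic carbon would give, and so whether the number falls gradually between methyl and tert-butyl or only at tert-butyl. Also open, as far as these compounds go, are a carboxylic acid or an amine on the aryl group at the amide-type nitrogen, and a longer chain in place of the ethyl group that all four compounds share.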